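Swapping a basic side chain for a carboxylic acid

A few compounds are considered here, and "the series" means these few. Any claim that something is new, unique, unknown or untested is made for them only; others in the source may bear on it.

Of the compounds shown here, three sharing a common core have been tested in a functional assay on THP-1 cells (Homo sapiens) for inhibition, read by sulforhodamine B assay, with a stated time of 48 h; on this read-out lower numbers stand for stronger inhibition and higher numbers for weaker inhibition. Compound 1 `COc1ccc(/C(=N/OC(C)=O)c2cccc3ccccc23)c(OC)c1OC` carries an oxime ester and gives > 20000 nM, which is a limit of the assay rather than a number. Compound 2 `COc1ccc(C(O)(C/C=C\c2ccccc2)c2cccc3ccccc23)c(OC)c1OC` gives 19400 nM in this assay. Compound 3 `COc1ccc(C(c2ccc(OC(C)CN(C)C)cc2)c2cccc3ccccc23)c(OC)c1OC`, whose side chain ends in a dimethylamino group, gives 15000 nM in this assay. Among the two numbers shown, compound 3 has the lower one, but its gap to compound 2 lies within the usual scatter, so the two cannot be ranked against each other. For the measured compounds named here, the one remaining value is a limit: the limit of > 20000 nM in this assay, at which 1 of the 3 values shown sits.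

Compound 4 `COc1ccc(C(c2ccc(OCC(=O)O)cc2)c2cccc3ccccc23)c(OC)c1OC` differs from compound 3 in a single place: carboxymethyl in place of 1-((dimethylamino)methyl)ethyl on an oxygen on an aromatic ring. The basic amine is gone and an acid takes its place on the same oxygen.

Going by the values given here, no step between two measured compounds is available to guide the estimate, and none of the measured compounds carries an acid. The side chains seen so far all give weak inhibition in this assay, so compound 4 is expected to fall in the same weak region or beyond it, with a real chance that only a limit is reported. The estimated step of a 1.7-fold higher number from compound 3 to compound 4 (0.22 log units; within the scatter) points toward weaker inhibition. Compound 4 is expected to give about 25000 nM, within a range from 8000 nM to 80000 nM.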

Compound 4, half-maximal inhibitory concentration: > 20000 nM
Compound 4: only a limit was reported; the forecaster's own chance of this, stated with the estimate: 55%; the middle value does not contradict the limit.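

In this assay compound 4 gives > 20000 nM, which is a limit of the assay and not a number. The step reads an at least 1.3-fold higher number from compound 3 to compound 4 (0.12 log units; that floor lies within the scatter), so on this oxygen on an aromatic ring, carboxymethyl in place of 1-((dimethylamino)methyl)ethyl brings no stronger inhibition, although this floor alone does not separate the two compounds. The change from an amine chain to a carboxylic acid therefore gives no gain at this position, and compound 4 joins compound 1 at the same limit: the limit of > 20000 nM in this assay, at which 2 of the 4 values shown sit.

As far as these compounds go, how far the true value of compound 4 lies from that limit stays unknown, so the real size of the step cannot be told and could be anything from a change within the scatter to a much larger one. From the compounds shown here alone, it also stays open whether other groups on the same oxygen, such as an amide, a simple methyl ether or a longer chain ending in an amine, would change inhibition in this assay at all.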